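Shortening the alkyl chain of compound 1

The source may report more compounds than this note shows. Statements on the series, on what has been measured and on what is new or still open speak of the compounds shown alone.

Among the measured compounds shown here, in a functional assay on MCF7 cells (Homo sapiens) for inhibition, read by MTT assay, with stated times of 18 h and 4 h (a lower number here means a stronger inhibitor, a higher number a weaker inhibitor), compound 1 (`CCCCCCCCCCOP(=O)(O)OCCSC(=S)N1CCCCCC1`) gives 43300 nM and stands at the low end of the three numbers so far. Compound 2 (`CCCCCCCCCCOP(=O)(O)OCCSC(=S)N1CCCC1`) gives 70000 nM and stays within the scatter of compound 1. Compound 3 (`CCCCCCCCCCOP(=O)(O)OCCSC(=S)N1CCN(C)CC1`) gives 99600 nM and is set apart from compound 1 only.

The next change leaves the azepan-1-yl group in place and moves to the chain: hydrogen in place of ethyl on a saturated chain carbon, eight bonds along the chain from an oxygen on an unsaturated carbon leads from compound 1 to compound 4 (`CCCCCCCCOP(=O)(O)OCCSC(=S)N1CCCCCC1`).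

All measured steps sit on the thiocarbonyl carbon, and none touches the chain, so they offer a sense of scale only. The two that start from compound 1 are a 1.6-fold higher number from compound 1 to compound 2 (0.21 log units; within the scatter) and a 2.3-fold higher number from compound 1 to compound 3 (0.36 log units; beyond the scatter) in size. Going by these compounds, the direction of a chain change is untested here, but a modest move towards a higher number in this assay is expected. The expected step is a 2.1-fold higher number from compound 1 to compound 4 (0.32 log units; beyond the scatter) on this reasoning. Compound 4 is estimated at 90000 nM with an expected range from 40000 nM to 200000 nM as a working figure.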

Compound 4, half-maximal inhibitory concentration: 78000 nM
For compound 4 the middle estimate is 1.2-fold (0.06 log units) above the measured one; the measured number falls inside the stated range.
By their numbers in this assay, from the lowest: compounds 1, 2, 4 and 3 (each within the scatter of the next, the first and the last beyond it).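

In this assay, among the compounds shown here, the first step on the chain itself is a 1.8-fold higher number from compound 1 to compound 4 (0.26 log units; within the scatter) with the azepan-1-yl group held constant. Hydrogen in place of ethyl at this place, on a saturated chain carbon, eight bonds along the chain from an oxygen on an unsaturated carbon, therefore gives a number that cannot be told apart from that of compound 1. This single pair shows no measurable dependence on this chain change, though it sets no trend for the chain as a whole. No supporting data bear on this result.

Going by these compounds, a longer chain, or a chain ending in an amine or a carboxylic acid, remains open. So does whether pyrrolidin-1-yl or 4-methylpiperazin-1-yl on the thiocarbonyl carbon would behave the same way with the chain of compound 4.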